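This account rests on a few compounds, and the source may have more. Where it says the series, first, only, none or still open, it means among the compounds named here.

Of the compounds shown here, two with a shared core have been measured in a functional assay on BGC-823 cells (Homo sapiens) for inhibition, read by MTT assay, with a stated time of 72 h; a lower number here means a stronger inhibitor, a higher number a weaker inhibitor. Compound 1 `Cc1cc(N2CC[C@@H](C)[C@@H](N(C)c3ncnc4[nH]ccc34)C2)n2nc(SCc3ccc(F)cc3)nc2n1` gives 44300 nM in this assay. Compound 2 `CCCCCc1c(C)nc2nc(SCc3ccc(Cl)cc3)nn2c1N1CC[C@@H](C)[C@@H](N(C)c2ncnc3[nH]ccc23)C1` differs from compound 1 in several places at once; in this assay compound 2 gives 32300 nM. The gap between these two numbers lies within the scatter of the method, so the two compounds stand together at a weak level of inhibition and no ordering between them can be drawn.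

Compound 3 `Cc1cc(N2CC[C@@H](C)[C@@H](N(C)c3ncnc4[nH]ccc34)C2)n2nc(SCc3ccc([N+](=O)[O-])cc3)nc2n1` has not yet been measured. It differs from compound 1 in one place: nitro in place of fluoro on an aromatic carbon. The change sits on the six-membered aromatic ring of carbon only, para to a large group, at the far end of the sulfanyl-linked benzyl arm.

Among the measured compounds shown here, since no pair of measured compounds differing only in this place is available, there is nothing in the numbers to point to a direction. The step from compound 1 to compound 3 is therefore expected to be small, a 1.1-fold lower number from compound 1 to compound 3 (0.04 log units; within the scatter), and not clearly beyond the scatter. Compound 3 is expected to give about 40000 nM in this assay, with a range from 15000 nM to 110000 nM.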

Compound 3, half-maximal inhibitory concentration: 59600 nM
Beside the measured number, compound 3's estimate is 1.5-fold (0.17 log units) below it; measured number inside the range.
By their numbers in this assay, from the lowest: compounds 2, 1 and 3 (each within the scatter of the next).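

Read in this assay, the change from fluoro to nitro gives a 1.3-fold higher number from compound 1 to compound 3 (0.13 log units; within the scatter) and so offers the only reading so far of this position on its own. The 4-fluorobenzyl and 4-nitrobenzyl arms thus stand together at the same weak level, even though nitro brings three heavy atoms and two hydrogen-bond acceptors in place of a single fluorine and none, so this one pair gives no sign that the aromatic carbon at the far end of the sulfanyl-linked arm governs the number. Nothing measured alongside these compounds speaks to why the two stand level.

The compounds shown leave open whether an amine or a carboxylic acid on this same aromatic carbon would carry the number away from this weak level, since a single pair cannot stand for the position as a whole. They also leave open which part of the molecule, if any, sets that level, as compound 2 differs from compound 1 in several places at once and no single change can be read from it.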